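The source may hold more compounds than are shown below. What is called first, only, known or untested is meant among the compounds shown, and "the series" means these compounds.

The series shares one core, seen in compound 1 `COc1ccc(/C=C/C(=O)c2ccc[nH]2)cc1Br`, compound 2 `CN(C)c1ccc(/C=C/C(=O)c2ccc[nH]2)cc1`, compound 3 `COc1cccc(OC)c1/C=C/C(=O)c1ccc[nH]1` and the still unmeasured compound 4 `COc1ccc(/C=C/C(=O)c2ccc[nH]2)cc1`, and is followed in an assay for inhibition of cytochrome P450 1A1 (Homo sapiens), read by fluorescence, using microsomes, with a stated time of 10 min; a lower number here means a stronger inhibitor, a higher number a weaker inhibitor. In this assay compound 1 reaches only a limit of the assay, > 20000 nM. Compound 2 likewise gives only a limit, > 20000 nM. Compound 3 gives a number, 10800 nM in this assay. Compound 2 thus stands at the limit of > 20000 nM in this assay, at which 2 of the 3 values shown sit, with no number of its own. Compound 4 differs from compound 2 by methoxy in place of dimethylamino on an aromatic carbon. Among the compounds with values here, no step between measured compounds is available, so the change is expected to stay within the usual scatter, with no clear direction. The expected step is an at least 1.3-fold lower number from compound 2 to compound 4 (0.12 log units; that floor lies within the scatter). Compound 4 is expected to give about 15000 nM in this assay, within 5000 nM to 40000 nM.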

Compound 4, half-maximal inhibitory concentration: > 20000 nM
Compound 4: no number, only a limit; the forecaster's own chance of this, stated with the estimate: 45%; middle value at least 1.3-fold (0.12 log units) from the limit.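

Compound 4, like compound 1 and compound 2, gives only a limit in this assay, so the steps from compound 1 and compound 2 to compound 4 cannot be read. From the compounds shown here alone, whether methoxy in place of dimethylamino, or hydrogen in place of bromo, changes inhibition at all stays open.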